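Amide side-chain changes in a small series

This account rests on a few compounds, and the source may have more. Where it says the series, first, only, none or still open, it means among the compounds named here.

compound 1 `CCn1c(C(=O)NCCCN(C)C)ccc1C(CC)(CC)c1ccc(OCC(O)C(C)(C)C)c(C)c1` gives 3100 nM
compound 2 `CCn1c(C(=O)NCC(OC)OC)ccc1C(CC)(CC)c1ccc(OCC(O)C(C)(C)C)c(C)c1` gives 14600 nM

In a functional assay on PC-3 cells (Homo sapiens), read by MTT assay, with a stated time of 48 h (on this read-out higher numbers stand for weaker inhibition and lower numbers for stronger inhibition), compound 2 stands at 14600 nM, the higher of the two numbers. Compound 3 `CCn1c(C(=O)N(CCC#N)CCC#N)ccc1C(CC)(CC)c1ccc(OCC(O)C(C)(C)C)c(C)c1` differs from compound 2 by a group of 9 heavy atoms (6 carbon, 3 nitrogen; no ring) in place of a group of 7 heavy atoms (4 carbon, 1 nitrogen, 2 oxygen; no ring), on a carbonyl carbon. Going by the values given here, the only measured step that bears on this is a 4.7-fold higher number from compound 1 to compound 2 (0.67 log units; beyond the scatter), which also lies in the group on the carbonyl carbon. That single step gives no direction for the new change, so no step beyond the scatter is expected in this assay. The expected change is a 1.3-fold lower number from compound 2 to compound 3 (0.12 log units; within the scatter). For compound 3 the estimated value is 11000 nM, with an expected range from 4500 nM to 27000 nM.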

Compound 3, half-maximal inhibitory concentration: 7800 nM
Beside the measured number, compound 3's estimate is 1.4-fold (0.15 log units) above it; measured number inside the range.
By their numbers in this assay, from the lowest: compound 1; then compounds 3 and 2 (each within the scatter of the next).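

In this assay, the nitrile-bearing group of 9 heavy atoms on the carbonyl carbon gives a 1.9-fold lower number from compound 2 to compound 3 (0.27 log units; within the scatter), so it is not separated from the (2,2-dimethoxyethyl)amino group. Set against the side chain of compound 1, the same group gives a 2.5-fold higher number from compound 1 to compound 3 (0.40 log units; beyond the scatter), which leaves compound 1 with the lowest number of the three. Nothing available accounts for these differences.

On these data alone, whether the lower number of compound 1 goes with its dimethylamino end remains open. A carboxylic acid or a morpholine at the end of the same chain would test this.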